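The source may hold more compounds than are shown below. What is called first, only, known or untested is meant among the compounds shown, and "the series" means these compounds.

Compound 1 `O=C(O)c1cc(=O)c2c(OCCOc3ccccc3)cccc2o1`: 100 ug/mL
Compound 2 `O=C(O)c1cc(=O)c2c(OCCCOc3ccccc3)cccc2o1`: 35 ug/mL
Compound 3 `O=C(O)c1cc(=O)c2c(OCCCCCOc3ccccc3)cccc2o1`: not yet measured

Within the data shown here, in a functional assay on ileum (Cavia porcellus) for antagonist activity, with a stated time of 30 s (on this read-out higher numbers stand for weaker inhibition and lower numbers for stronger inhibition), compound 2 gives 35 ug/mL, the lower of the two numbers so far. The change to compound 3 is 2-phenoxyethyl in place of phenoxy on a saturated chain carbon, three bonds along the chain from an oxygen on an aromatic ring, on a saturated chain carbon, three bonds along the chain from an oxygen on an aromatic ring. Among the measured compounds shown here, only one measured step bears on this: a 2.9-fold lower number from compound 1 to compound 2 (0.46 log units; beyond the scatter), a modest step that also extends the chain. A single step fixes no trend, but a further lowering of similar size is expected in this assay. The expected step is a 2.3-fold lower number from compound 2 to compound 3 (0.37 log units; beyond the scatter). The estimated value for compound 3 is 15 ug/mL, with an expected range of 5 ug/mL to 50 ug/mL.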

Compound 3, half-maximal inhibitory concentration: 17.5 ug/mL
For compound 3 the middle estimate is 1.2-fold (0.07 log units) below the measured one, and the stated range covers the measured number.
By their numbers in this assay, from the lowest: compounds 3 and 2 (each within the scatter of the next); then compound 1.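

In this assay, 2-phenoxyethyl in place of phenoxy at this place gives a 2.0-fold lower number from compound 2 to compound 3 (0.30 log units; within the scatter) and leaves compound 3 not distinguishable from compound 2. The chain extension that gave a 2.9-fold lower number from compound 1 to compound 2 (0.46 log units; beyond the scatter) was a resolved step, but this further extension is not, so a steady chain-length trend across the three compounds is not supported. No measurement here bears on the reason for this.

Open, from the compounds shown here alone, is whether a longer chain would give a number clearly separate from compound 3. Also open, going by these compounds, is how an amine in the chain in place of the phenoxy oxygen would read.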